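The compounds below may be only part of what the source reports. "The series", "measured", "known", "first", "only" and "open" are said of these compounds alone.

Series notes. Compound 1 `Cc1c(C(=O)N/N=C\c2ccco2)oc2cccc(O)c12` carries the shared core with a furan-2-yl on the carbon with a double bond to nitrogen. In a functional assay on PC-3 cells (Homo sapiens) for inhibition (a lower number here means a stronger inhibitor, a higher number a weaker inhibitor), compound 1 gives only a limit, >= 40000 nM. Compound 2 `Cc1c(C(=O)N/N=C\c2cccnc2)oc2cccc(O)c12` has pyridin-3-yl in that place. In this assay compound 2 likewise gives only a limit, >= 40000 nM. The step that the two limits leave unreadable from compound 1 to compound 2 is therefore not readable; the limit of >= 40000 nM in this assay, at which 2 of the 2 values shown sit, places both values at the same boundary, so compound 2 stands at that boundary alongside compound 1 with nothing to separate them.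

Compound 3 `Cc1c(C(=O)N/N=C\c2ccccn2)oc2cccc(O)c12` is the next member. Its difference from compound 2 is pyridin-2-yl in place of pyridin-3-yl on a carbon with a double bond to nitrogen. Among the compounds with values here, the only measured step, from compound 1 to compound 2, is unreadable and concerns a different exchange; no measured step bears directly on the pyridin-3-yl to pyridin-2-yl exchange. Because compound 2 gives >= 40000 nM as a limit, compound 3 is expected to return a limit as well in this assay. The expected step of a number no higher from compound 2 to compound 3 (the limit leaves the size open) is none beyond the scatter. Compound 3 is thus estimated at 40000 nM, with a range of 15000 nM to 100000 nM.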

Compound 3, half-maximal inhibitory concentration: >= 40000 nM
Compound 3 ended at the assay's limit; the forecaster's own chance of this, stated with the estimate: 75%; the middle value lies on the limit itself.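

In this assay compound 3 gives >= 40000 nM, a limit and not a number, so the steps to compound 3 from compound 1 and from compound 2 cannot be read. All three compounds sit at one boundary: the limit of >= 40000 nM in this assay, at which 3 of the 3 values shown sit.

The compounds shown leave open whether any group on the carbon with a double bond to nitrogen gives a readable value in this assay.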